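Piperidinyl amide in place of chlorothiophene in the benzoxazole series

A few compounds are considered here, and "the series" means these few. Any claim that something is new, unique, unknown or untested is made for them only; others in the source may bear on it.

Of the compounds shown here, three have been measured in an assay on mitochondria for inhibition of HSP60/HSP10 (Homo sapiens); a higher number here means a weaker inhibitor, a lower number a stronger inhibitor. Compound 1 `O=S(=O)(Nc1ccc(-c2nc3cc(NS(=O)(=O)c4ccccc4)ccc3o2)cc1)c1ccccc1` gives 86000 nM. Compound 2 `COc1ccc(S(=O)(=O)Nc2ccc3oc(-c4ccc(NC(=O)c5ccc(Cl)s5)cc4)nc3c2)cc1` gives 61000 nM, which is the second highest of the three numbers; compound 1 lies nearest and within the scatter of compound 2, so no order is read between them. For the measured compounds named here, compound 3 `O=S(=O)(Nc1ccc(-c2nc3cc(NS(=O)(=O)c4ccc(Cl)s4)ccc3o2)cc1)c1ccc(Cl)c(C(F)(F)F)c1` gives 6700 nM, the lowest number of the three and beyond the scatter from compound 2, but it differs from compound 2 in more than one place, so no single step is assigned to that gap.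

Compound 4 `COc1ccc(S(=O)(=O)Nc2ccc3oc(-c4ccc(NC(=O)C5CCN(C(C)=O)CC5)cc4)nc3c2)cc1` is not yet measured. It differs from compound 2 at one place: 1-acetylpiperidin-4-yl in place of 5-chlorothiophen-2-yl on a carbonyl carbon. Going by the values given here, no measured pair carries this change, so there is no reference step. Swapping an aromatic ring for a non-aromatic acetylated ring at the carbonyl carbon is expected to shift this assay only modestly, towards a higher number, with a 1.6-fold higher number from compound 2 to compound 4 (0.21 log units; within the scatter) as the expected step from compound 2 to compound 4, close to the edge of the scatter. Compound 4 is accordingly estimated at 100000 nM, with a range from 40000 nM to 250000 nM.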

Compound 4, half-maximal inhibitory concentration: 24000 nM
The estimate for compound 4 lay 4.2-fold (0.62 log units) above the measured number; measured number outside the range, below it.
By their numbers in this assay, from the lowest: compound 3; then compound 4; then compounds 2 and 1 (each within the scatter of the next).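

With 1-acetylpiperidin-4-yl in place of 5-chlorothiophen-2-yl on a carbonyl carbon, this assay gives a 2.5-fold lower number from compound 2 to compound 4 (0.41 log units; beyond the scatter). For the compounds shown here, this is the first single-place step, and it shows that this position can shift the number beyond the scatter with the rest of compound 2 unchanged, and that an aromatic ring is not needed here for the number to fall. Nothing measured on these compounds accounts for the direction of the step.

Separating the part played by the acetyl group from that of the piperidine ring would take a comparison with the free piperidine amine or a cyclohexyl ring on the same carbonyl carbon. Going by these compounds, how a carboxylic acid or a longer chain in place of the acetyl group would read in this assay also stays open.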